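The source may report more compounds than this note shows. Statements on the series, on what has been measured and on what is new or still open speak of the compounds shown alone.

Compound 2, with the structure `CC(C)(C)c1[nH]cnc1/C=c1\[nH]c(=O)/c(=C/c2cccc(Oc3ccc(F)cc3)c2)[nH]c1=O`, and compound 1, with the structure `CC(C)(C)c1[nH]cnc1/C=c1\[nH]c(=O)/c(=C/c2cccc(C(=O)c3ccc(F)cc3)c2)[nH]c1=O`, share one core and differ only in one group: (4-fluorophenyl)carbonyl in place of 4-fluorophenoxy on an aromatic carbon. In a functional assay on NCI-H460 cells (Homo sapiens) for cytotoxicity, read by MTT assay, with a stated time of 72 h (a higher number here means a weaker inhibitor, a lower number a stronger inhibitor), compound 2 gives 4 nM, and compound 1 gives 3.8 nM, so the change made a 1.1-fold lower number from compound 2 to compound 1 (0.02 log units; within the scatter).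

Compound 3, with the structure `Cc1ccc(/C=c2\[nH]c(=O)/c(=C/c3cccc(Oc4ccc(F)cc4)c3)[nH]c2=O)o1`, carries a different core, and how the two cores differ is this: 5-methylfuran-2-yl in place of 5-(tert-butyl)-1H-imidazol-4-yl on a double-bonded chain carbon bound to an aromatic carbon. In this assay compound 3 gives 30 nM, which is the highest number among the three measured compounds, a step of a 7.5-fold higher number from compound 2 to compound 3 (0.88 log units; beyond the scatter).

Compound 4, with the structure `Cc1ccc(/C=c2\[nH]c(=O)/c(=C/c3cccc(C(=O)c4ccc(F)cc4)c3)[nH]c2=O)o1`, has not yet been measured. It stands to compound 3 as compound 1 stands to compound 2: (4-fluorophenyl)carbonyl in place of 4-fluorophenoxy on an aromatic carbon. The place of the change is the same in both pairs, so this is the same change made on the core of compound 3. The step is expected to be about a 1.1-fold lower number from compound 3 to compound 4 (0.05 log units; within the scatter), beside the earlier one, because the same change gave a 1.1-fold lower number from compound 2 to compound 1 (0.02 log units; within the scatter), a step within the scatter. On that basis compound 4 is expected to give about 27 nM in this assay, most likely between 10 nM and 75 nM.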

Compound 4, half-maximal inhibitory concentration: 5.3 nM
Estimate against measurement, compound 4: 5.1-fold (0.71 log units) above, and the stated range ends above it.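

In this assay, putting (4-fluorophenyl)carbonyl in place of 4-fluorophenoxy on the methylfuran-bearing core gave a 5.7-fold lower number from compound 3 to compound 4 (0.75 log units; beyond the scatter), so the effect of this change did not carry over unaltered from one core to the other: the same change on two cores in this assay, a 1.1-fold lower number (0.02 log units; within the scatter) from compound 2 to compound 1 and a 5.7-fold lower number (0.75 log units; beyond the scatter) from compound 3 to compound 4, 5.4-fold (0.73 log units) apart, beyond the scatter of two such steps

The same four compounds can be read the other way: 5-methylfuran-2-yl in place of 5-(tert-butyl)-1H-imidazol-4-yl gave a 1.4-fold higher number from compound 1 to compound 4 (0.14 log units; within the scatter) with the (4-fluorophenyl)carbonyl group present, so the cost of that swap seen with 4-fluorophenoxy did not appear here: the same change on two cores in this assay, a 7.5-fold higher number (0.88 log units; beyond the scatter) from compound 2 to compound 3 and a 1.4-fold higher number (0.14 log units; within the scatter) from compound 1 to compound 4, 5.4-fold (0.73 log units) apart, beyond the scatter of two such steps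

This shows that the two changes are not independent in these compounds, so adding up steps failed here, but a single set of four compounds does not show why, nor whether the same holds on any other core.

From the compounds shown here alone, it remains open whether a third core would follow the tert-butyl imidazole pair or the methylfuran pair. Going by these compounds, it is also open how an amine or a methylene group would behave in place of the carbonyl, and whether chlorine in place of fluorine would show the same dependence on the core.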